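Swapping the aryl ester group and maximal response

The source may report more compounds than this note shows. Statements on the series, on what has been measured and on what is new or still open speak of the compounds shown alone.

Measured so far:
compound 1, `COc1ccc(C(=O)OC(CCN(C)C)c2ccc(Cl)cc2)cc1`, 84%
compound 2, `Cc1ccsc1C(=O)OC(CCN(C)C)c1ccc(Cl)cc1`, 119%

Among the compounds with values here, in an assay on NIH3T3 cells with Urotensin-2 receptor (Homo sapiens) as the target (a higher number here means a larger maximal response, a lower number a smaller maximal response), compound 2 stands highest of the two numbers known, with compound 1 the nearest, a step of a number 35 percentage points higher from compound 1 to compound 2 (beyond the scatter). Compound 3, `Cc1ccc(C(=O)OC(CCN(C)C)c2ccc(Cl)cc2)cc1`, is not yet measured. It differs from compound 2 by 4-methylphenyl in place of 3-methylthiophen-2-yl on a carbonyl carbon. Within the data shown here, the only step that bears on this change is the one from compound 1 to compound 2, where a 4-methoxyphenyl gave way to the 3-methylthiophen-2-yl and the number rose by a large amount. Putting a phenyl ring back in is therefore expected to move the number downward beyond the scatter, by about a number 24 percentage points lower from compound 2 to compound 3 (beyond the scatter). For compound 3 a value near 95% is estimated, ranging from 75% to 118%.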

Compound 3, largest response reached (reported as efficacy), in percent of the reference or control that the assay uses: 56%
Beside the measured number, compound 3's estimate is 39 percentage points above it, outside the stated range (below it).
By their numbers in this assay, from the lowest: compound 3; then compound 1; then compound 2.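

In this assay, the number is a number 63 percentage points lower from compound 2 to compound 3 (beyond the scatter) when 4-methylphenyl replaces 3-methylthiophen-2-yl on a carbonyl carbon, so both phenyl esters now sit below the thiophene ester, compound 2. The group on the phenyl ring matters too: the number is a number 28 percentage points lower from compound 1 to compound 3 (beyond the scatter) with methyl in place of methoxy on an aromatic carbon. No available evidence explains either change. Still open, on these data alone, is how a plain phenyl, a 4-chlorophenyl or a thiophen-2-yl without its methyl group would compare on this carbonyl carbon.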